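From isobutyl to benzyl: compound 3 to compound 4

The compounds below may be only part of what the source reports. "The series", "measured", "known", "first", "only" and "open" are said of these compounds alone.

In a functional assay on HOS cells (Homo sapiens) for antiproliferative activity, read by sulforhodamine B assay (on this read-out lower numbers stand for stronger inhibition of growth and higher numbers for weaker inhibition of growth), compound 2 (`CC[C@@H]1O[C@H](COCc2ccccc2)[C@@H](OCc2ccccc2)[C@H](OCc2ccccc2)C1=O`) gives 4300 nM. Compound 1 (`CC[C@H]1O[C@H](COCc2ccccc2)[C@@H](OCc2ccccc2)[C@H](OCc2ccccc2)[C@H]1O`) gives > 50000 nM, which is a limit and not a number. Compound 3 (`CC(C)C[C@@H]1O[C@H](COCc2ccccc2)[C@@H](OCc2ccccc2)[C@H](OCc2ccccc2)C1=O`) gives > 50000 nM, again a limit and not a number, so it stands at the limit of > 50000 nM in this assay, at which 2 of the 3 values shown sit.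

Compound 4 (`O=C1[C@H](Cc2ccccc2)O[C@H](COCc2ccccc2)[C@@H](OCc2ccccc2)[C@@H]1OCc1ccccc1`) carries phenyl in place of isopropyl on a saturated chain carbon bound to a saturated ring carbon. The same difference, cut one bond further out, reads isobutyl to benzyl.

Among the compounds with values here, only one measured step bears on this place: an at least 11-fold higher number from compound 2 to compound 3 (1.06 log units; beyond the scatter). That step is large, so a sizeable change in this assay is plausible here, but it is a single example and it ends at a limit. A moderate move toward a lower number is expected, although another reading at the limit remains quite possible. The expected step is an at least 2.5-fold lower number from compound 3 to compound 4 (0.39 log units; beyond the scatter). For compound 4 the estimated value is 20000 nM, with an expected range from 4000 nM to 50000 nM.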

Compound 4, concentration for 50% growth inhibition: > 50000 nM
Compound 4: only a limit was reported; the forecaster's own chance of this, stated with the estimate: 40%; middle value at least 2.5-fold (0.39 log units) from the limit.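

In this assay the limit now also holds for compound 4: the limit of > 50000 nM in this assay, at which 3 of the 4 values shown sit.

Taken against methyl, phenyl reads as an at least 11-fold higher number from compound 2 to compound 4 (1.06 log units; beyond the scatter). An aromatic ring at this place therefore ends at the same limit as the branched isopropyl group, so the loss of growth inhibition at this position is no longer tied to a single group. The step between compound 3 and compound 4 cannot be read, as both values are limits, and no order between isopropyl and phenyl can be given.

Within the data shown here, compound 2 remains the only compound of this set at this position with a number, 4300 nM, so the series has a single reference point. On these data alone, how an amine or a carboxylic acid on this chain would read remains open.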